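The compounds below may be only part of what the source reports. "The series", "measured", "known", "first", "only" and "open" are said of these compounds alone.

Compound 1 `O=C(O)c1cc(NC(=O)c2ccc([N+](=O)[O-])cc2)cc(C(=O)O)c1`: 9.8 mg/kg; compound 2 `NC(=O)c1ccc(NC(=O)c2ccc(-c3nn[nH]n3)cc2)cc1`: 2 mg/kg.

In a functional assay on the whole organism with Rattus norvegicus as the target, at a dose of 25 mg/kg by the intravenous route (on this read-out lower numbers stand for an effect already at smaller amounts and higher numbers for an effect only at larger amounts of compound), compound 1 gives 9.8 mg/kg, the highest of the two numbers recorded, while compound 2 gives 2 mg/kg, a lower number by a margin beyond the scatter. Compound 3 `N#Cc1ccc(C(=O)Nc2cc(C(=O)O)cc(C(=O)O)c2)cc1` has not yet been measured. It differs from compound 1 in one place: cyano in place of nitro on an aromatic carbon. Among the measured compounds shown here, no measured pair shows this change, so its effect cannot be read from the data. Compound 3 is expected to stay close to compound 1, with an estimated step of a 1.1-fold lower number from compound 1 to compound 3 (0.04 log units; within the scatter) that does not exceed the scatter. The estimate for compound 3 is 9 mg/kg, with a range from 4 mg/kg to 20 mg/kg.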

Compound 3, dose for 50% inhibition: 1.7 mg/kg
The estimate for compound 3 lay 5.3-fold (0.72 log units) above the measured number, outside the stated range (below it).
By their numbers in this assay, from the lowest: compounds 3 and 2 (each within the scatter of the next); then compound 1.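

In this assay, putting cyano in place of nitro on this aromatic carbon, para to a large group, gives a 5.8-fold lower number from compound 1 to compound 3 (0.76 log units; beyond the scatter). The earlier compounds shown here could not show this: the group at this carbon matters to the read-out, and here the swap of nitro for cyano lowers the number beyond the scatter. Nothing measured here accounts for this step.

As far as these compounds go, whether a chlorine atom, a methyl group or an amine on this carbon would give a number nearer compound 3 or compound 1 stays open. So does whether the same swap would have a similar effect on a different core.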